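Epimer at the methyl-bearing carbon in an aryl-cyclohexyl acid series

The source may report more compounds than this note shows. Statements on the series, on what has been measured and on what is new or still open speak of the compounds shown alone.

Compound 1: `COc1ccc(F)c([C@H]2CC[C@H](COc3cccc([C@@H](CC(=O)O)C4CC4)c3)CC2)c1`, 199 nM
Compound 2: `COc1ccc(F)c([C@H]2CC[C@H](COc3cccc([C@H](C4CC4)[C@H](C)C(=O)O)c3)CC2)c1`, 2 nM
Compound 3: `COc1ccc(F)c([C@H]2CC[C@H](COc3cccc([C@H](C4CC4)[C@@H](C)C(=O)O)c3)CC2)c1`, not yet measured

For the measured compounds named here, in a functional assay on cells for agonist activity at Free fatty acid receptor 1 (Homo sapiens), read by HTRF and inositol phosphate accumulation, with a stated time of 90 min (on this read-out lower numbers stand for an effect already at smaller amounts and higher numbers for an effect only at larger amounts of compound), compound 2 gives the lowest of the two numbers; its nearest neighbour is compound 1, and the change a 100-fold lower number from compound 1 to compound 2 (2.00 log units; beyond the scatter) is the only measured step in the set. Compound 3 differs from compound 2 in that (the two compounds have the same atoms and bonds and differ only in configuration as drawn: 1 of 4 stereo elements differ; a stereocentre at a saturated chain carbon is drawn S in compound 2 and R in compound 3). Going by the values given here, no measured step covers a change of configuration alone, so the expectation rests on the fact that the methyl-bearing stereocentre as drawn in compound 2 carries a large gain over compound 1. For compound 3 the estimate is 150 nM (range 20 nM to 1500 nM), a step of a 75-fold higher number from compound 2 to compound 3 (1.88 log units; beyond the scatter) that is expected to lose most of that gain.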

Compound 3, half-maximal effective concentration: 22 nM
Estimate against measurement, compound 3: 6.8-fold (0.83 log units) above; measured number inside the range.
By their numbers in this assay, from the lowest: compound 2; then compound 3; then compound 1.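

In this assay the methyl group also gives a gain in the R configuration: a 9.0-fold lower number from compound 1 to compound 3 (0.96 log units; beyond the scatter) shows that the gain is not confined to S. Configuration at this carbon still matters, and an 11-fold higher number from compound 2 to compound 3 (1.04 log units; beyond the scatter) leaves S as drawn the better of the two. That gap comes down to this stereocentre alone: the fact that compounds 2 and 3 differ only in the configuration as drawn.

Open, as far as these compounds go, is whether an ethyl or hydroxyl group on this carbon would keep the gain in either configuration. Also open, from the compounds shown here alone, is whether the preference for S holds when the other stereocentres change.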